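This account rests on a few compounds, and the source may have more. Where it says the series, first, only, none or still open, it means among the compounds named here.

Compound 1, `COc1ccc(C2SCC(=O)N2CCN2CCCCC2)cc1`, was tested in an ADME assay on Vero cells (Chlorocebus sabaeus) for cytotoxicity, read by neutral red uptake, tested at 787 ug/mL (a higher number here means a weaker effect of the compound at the concentration tested, a lower number a stronger effect), where compound 1 gives 33%. Among the two compounds measured so far, its number sits at the top, yet the gap to its nearest neighbour lies within the usual scatter of repeated measurements, so neither can be called stronger or weaker. That neighbour, compound 2, `O=C1CSC(c2cccc(Cl)c2)N1CCN1CCCCC1`, gives 31% in this assay.

The next compound, compound 3, `O=C1CSC(c2ccc(Cl)cc2)N1CCN1CCCCC1`, has not yet been measured in this assay. The change from compound 1 to compound 3 is chloro in place of methoxy on an aromatic carbon. Among the compounds with values here, no pair of measured compounds differing in just one place exists here, so the size of such a step cannot be read from a measured example. Within the data shown here, the only guide is that compound 2 also carries a chloro on its ring and gives 31%, a number that sits within the scatter of compound 1. The step from compound 1 to compound 3 is therefore expected to be small, a number 1 percentage points lower from compound 1 to compound 3 (within the scatter), with no direction beyond the scatter. Compound 3 is expected to give about 32%, within a range from 18% to 46%.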

Compound 3, a percentage reported as activity, at one concentration (the size of the read-out at that concentration, not a potency): 15%
For compound 3 the middle estimate is 17 percentage points above the measured one; the measured number lies below the stated range.
By their numbers in this assay, from the lowest: compound 3; then compounds 2 and 1 (each within the scatter of the next).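

In this assay, the group on the aromatic ring proves able to move the read-out: chloro in place of methoxy, on the aromatic carbon para to a large group, gives a number 18 percentage points lower from compound 1 to compound 3 (beyond the scatter), a stronger effect at the concentration tested. The earlier compounds shown here could not show that the location of the chloro also counts, but 4-chlorophenyl in place of 3-chlorophenyl gives a number 16 percentage points lower from compound 2 to compound 3 (beyond the scatter), so carrying a chloro does not by itself fix the number, and these two compounds with the same atoms are told apart by where the chloro sits. No measurement shown here offers an explanation for either step.

From the compounds shown here alone, it remains open whether this stronger effect is special to chloro or would also appear with another group at the same place, such as fluoro, bromo, methyl, trifluoromethyl or a nitrile. Also unsettled is what an amine or a carboxylic acid would do there, and whether the size of these steps would carry over to a different group on the ring nitrogen of the shared core.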